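Swapping a chloro-substituted ring for a short branched chain

The compounds below may be only part of what the source reports. "The series", "measured", "known", "first", "only" and "open" are said of these compounds alone.

Compound 1 `[O-][n+]1nc(NCOCc2ccc(Cl)cc2)[n+]([O-])c2ccccc21`: 2190 nM
Compound 2 `CC(OCNc1n[n+]([O-])c2ccccc2[n+]1[O-])c1ccccc1`: 2810 nM

In a functional assay on A549 cells (Homo sapiens) for cytotoxicity, read by MTT assay, with a stated time of 72 h (on this read-out lower numbers stand for stronger inhibition and higher numbers for weaker inhibition), compound 1 gives 2190 nM and compound 2 gives 2810 nM; the two numbers lie within the usual scatter of one another, so neither compound can be set apart on this read-out. Compound 3 `CC(C)CCOCNc1n[n+]([O-])c2ccccc2[n+]1[O-]` has not yet been tested. It differs from compound 1 by isobutyl in place of 4-chlorophenyl on a saturated chain carbon bound to an oxygen on a saturated carbon. Among the measured compounds shown here, no measured pair shows the effect of such a change here. For compound 3 the expected outcome is a modest move toward weaker inhibition, a 1.6-fold higher number from compound 1 to compound 3 (0.20 log units; within the scatter), with a wide range. The estimate for compound 3 is 3500 nM, between 1200 nM and 10000 nM.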

Compound 3, half-maximal inhibitory concentration: 2110 nM
Estimate against measurement, compound 3: 1.7-fold (0.22 log units) above; measured number inside the range.
By their numbers in this assay, from the lowest: compounds 3, 1 and 2 (each within the scatter of the next).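

In this assay putting isobutyl in place of 4-chlorophenyl on a saturated chain carbon bound to an oxygen on a saturated carbon gives a 1.0-fold lower number from compound 1 to compound 3 (0.02 log units; within the scatter) and so leaves the reading within the scatter. For this pair, an aromatic ring with its chlorine is therefore not needed at this position to keep the number in the same range. Nothing available explains why these two different groups read alike. As far as these compounds go, whether an amine, a carboxylic acid or a longer chain would also fit at this position remains open. So does whether this match holds in other cell lines.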